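A fluorine swap among compounds known only by limits

The compounds below may be only part of what the source reports. "The series", "measured", "known", "first", "only" and "open" are said of these compounds alone.

Measured so far in a toxicity assay on NIH3T3 cells (Mus musculus) for cytotoxicity, read by resazurin assay (a higher number here means that more compound is needed for the effect, a lower number that less compound is needed), and given as limits, not numbers:
- Compound 1 `COC(=O)c1ccc(NCc2cncn2Cc2ccc(N)cc2)cc1-c1ccccc1` gives > 10000 nM as a limit
- Compound 2 `COC(=O)c1ccc(NCc2cncn2Cc2ccc([N+](=O)[O-])cc2)cc1-c1ccccc1` gives > 10000 nM as a limit
- Compound 3 `COC(=O)c1ccc(NCc2cncn2Cc2cccc(C(C)(C)C)c2)cc1-c1ccccc1` gives > 1000 nM as a limit

Compound 3 stands at the limit of > 1000 nM in this assay, at which 1 of the 3 values shown sits, and has only a limit to its name. Compound 1 and compound 2 stand at the limit of > 10000 nM in this assay, at which 2 of the 3 values shown sit, and have only limits as well. Within the data shown here, no compound here can therefore be ranked against another.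

Compound 4 `COC(=O)c1ccc(NCc2cncn2Cc2ccc(F)cc2F)cc1-c1ccccc1` has not yet been measured. It carries 2,4-difluorophenyl in place of 3-(tert-butyl)phenyl on a saturated chain carbon bound to an aromatic nitrogen.

Two measured steps change the group at that same place (a step that the two limits leave unreadable from compound 1 to compound 3) and (a step that the two limits leave unreadable from compound 2 to compound 3). A third puts nitro in place of amino on an aromatic carbon (a step that the two limits leave unreadable from compound 1 to compound 2). None of the three has a readable size, so together they point in no direction. All three compounds have so far returned only limits, and another limit is the most likely result here.

Among the measured compounds shown here, no step of measurable size can be expected, and the estimate is (a step that the limit leaves unreadable from compound 3 to compound 4). For compound 4 the estimated value is 10000 nM with an expected range from 3000 nM to 30000 nM in this assay when it is measured.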

Compound 4, half-maximal effective concentration: > 1000 nM
Compound 4 was reported as a limit; the forecaster's own chance of this, stated with the estimate: 80%; the middle value lies beyond the limit too.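

In this assay compound 4 gives > 1000 nM, which is a limit and not a number. Among these compounds, compound 1, compound 2 and compound 3 also have only limits, and no step from any of them to compound 4 can be read. The compounds shown leave open how much of each is needed for the effect, and whether changing the group on the saturated chain carbon alters that amount.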